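Swapping the phenyl group of compound 1

A few compounds are considered here, and "the series" means these few. Any claim that something is new, unique, unknown or untested is made for them only; others in the source may bear on it.

Within the data shown here, in an ADME assay on MCF7-DOX cells (Homo sapiens) for cytotoxicity, read by MTT assay, with a stated time of 48 h (on this read-out lower numbers stand for stronger inhibition and higher numbers for weaker inhibition), compound 1 `COc1cc(OC)c(C(=O)/C=C/c2ccc(C(F)(F)F)cc2)c(O)c1CC=C(C)C` gives 73700 nM, the only true number among the three compounds measured so far. Compound 2 `CCCc1c(OC)cc(OC)c(C(=O)/C=C/c2cccc(N3CCNCC3)c2)c1O` reports only a limit of this assay, > 100000 nM. Compound 3 `CCCCCc1c(OC)cc(OC)c(C(=O)/C=C/c2cccc(N3CCNCC3)c2)c1O` also reports only a limit, > 100000 nM.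

Compound 4 `COc1cc(OC)c(C(=O)/C=C/c2cccc(Cl)c2)c(O)c1CC=C(C)C` keeps the core of compound 1 and changes one group: 3-chlorophenyl in place of 4-(trifluoromethyl)phenyl on a double-bonded chain carbon bound to a double-bonded chain carbon. Among the measured compounds shown here, the only measured step in this small set is a step that the two limits leave unreadable from compound 2 to compound 3. That step concerns a saturated chain rather than the phenyl group, and it offers no size to carry over. For the measured compounds named here, no measured step therefore bears directly on this swap, and neither direction is favoured. The best starting point remains compound 1 at 73700 nM. The step of a 1.1-fold lower number from compound 1 to compound 4 (0.02 log units; within the scatter) is expected to stay within the usual scatter of repeated measurements. Compound 4 is estimated at 70000 nM, with an expected range of 30000 nM to 100000 nM.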

Compound 4, half-maximal inhibitory concentration: 59500 nM
Compound 4: middle estimate off by 1.2-fold (0.07 log units), on the high side; measured number inside the range.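

Among these compounds, replacing 4-(trifluoromethyl)phenyl with 3-chlorophenyl at this place gives a 1.2-fold lower number from compound 1 to compound 4 (0.09 log units; within the scatter), the first step in this set with a readable size. In this assay, this swap therefore shows no real change: the two groups differ in their heavy atoms and in the substituent they carry, yet the read-out does not separate compound 1 from compound 4. The earlier compounds shown here could not show this, since no measured step among them had a size and none touched this phenyl group.

Going by these compounds, whether another group at this place would move the number beyond the scatter stays open, for example a phenyl ring bearing a nitrile or a carboxylic acid. The step between the other two compounds cannot be read, and much of this small set gives a limit, not a number: the limit of > 100000 nM in this assay, at which 2 of the 4 values shown sit.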